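Ester in place of carbonate on the shared core

The compounds below may be only part of what the source reports. "The series", "measured", "known", "first", "only" and "open" are said of these compounds alone.

Measured in an assay on COS-7 cells for inhibition of sodium/nucleoside cotransporter 2 (Homo sapiens), read by scintillation counting, in the presence of a further agent that is not named here; on this read-out higher numbers stand for weaker inhibition and lower numbers for stronger inhibition:
compound 1 `Nc1ncnc2c1nc(NCCCc1ccccc1)n2[C@@H]1O[C@H](CO)[C@@H](O)[C@H]1O` gives 536000 nM
compound 2 `CCOC(=O)OC[C@H]1O[C@@H](n2cnc3c(N)ncnc32)[C@H](O)[C@@H]1O` gives only a limit, > 100000 nM
compound 3 `COc1cccc(CNc2nc3c(N)ncnc3n2[C@@H]2O[C@H](CO)[C@@H](O)[C@H]2O)c1` gives 13000 nM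

Compound 2 sits at a limit of this assay, not at a number: the limit of > 100000 nM in this assay, at which 1 of the 3 values shown sits. For the measured compounds named here, compound 1 and compound 3 both give numbers, and the single measured step, a 41-fold lower number from compound 1 to compound 3 (1.62 log units; beyond the scatter), concerns the substituent on the aromatic nitrogen of the core, not the carbonyl carbon changed here. Compound 4 `CCCCCC(=O)OC[C@H]1O[C@@H](n2cnc3c(N)ncnc32)[C@H](O)[C@@H]1O` differs from compound 2 in one place: pentyl in place of ethoxy on a carbonyl carbon. Going by the values given here, no measured step bears on this change, so no direction beyond the scatter can be expected, and the result is expected to stay near the limit. Compound 4 is expected at 150000 nM, with a range from 40000 nM to 600000 nM. The implied step that the limit leaves unreadable from compound 2 to compound 4 is an estimate only.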

Compound 4, half-maximal inhibitory concentration: > 100000 nM
Compound 4: only a limit was reported; the forecaster's own chance of this, stated with the estimate: 65%; the middle value lies beyond the limit too.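

No step can be read between compound 2 and compound 4, since both stand at a limit: the limit of > 100000 nM in this assay, at which 2 of the 4 values shown sit.

Still open, as far as these compounds go, is whether pentyl or ethoxy on the carbonyl carbon gives the lower number, and how far past the limit either compound lies.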